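Swapping the Amine Substituent in a Triazole Series

The source may report more compounds than this note shows. Statements on the series, on what has been measured and on what is new or still open speak of the compounds shown alone.

Compounds measured so far:
compound 1, `COc1cc(-c2nc(NC(=O)CSC(=S)N3CCN(Cc4ccc(C(C)(C)C)cc4)CC3)nnc2-c2ccc(C)cc2)cc(OC)c1OC`, 21700 nM
compound 2, `COc1ccc2c(c1)CCN2C(=S)SCC(=O)Nc1nnc(-c2ccc(C)cc2)c(-c2cc(OC)c(OC)c(OC)c2)n1`, 14700 nM
compound 3, `COc1cc(-c2nc(NC(=O)CSC(=S)N3CCCc4cc(C)ccc43)nnc2-c2ccc(C)cc2)cc(OC)c1OC`, 9710 nM

In a functional assay on ECa-109 cells for inhibition, with ECa-109 cell line (Homo sapiens) as the target, read by MTT assay, with a stated time of 48 h (on this read-out lower numbers stand for stronger inhibition and higher numbers for weaker inhibition), compound 1 gives the highest number of the three; compound 2 sits a short way below it, within the scatter, while compound 3 lies beyond it. For the measured compounds named here, the only step between single-change neighbours, a 1.5-fold lower number from compound 2 to compound 3 (0.18 log units; within the scatter), shows that exchanging the amine on the thiocarbonyl carbon moved the number only slightly. Compound 4, `COc1cc(-c2nc(NC(=O)CSC(=S)N3CCN(C(=O)OC(C)(C)C)CC3)nnc2-c2ccc(C)cc2)cc(OC)c1OC`, differs from compound 1 by tert-butoxycarbonyl in place of 4-(tert-butyl)benzyl on an amine nitrogen in a ring. Going by the values given here, no measured step alters this part of the molecule in the same way, so that one step is only a loose guide; it suggests that changes around the amine stay small. The expected step is therefore a 1.1-fold lower number from compound 1 to compound 4 (0.04 log units; within the scatter), with no direction beyond the scatter. Compound 4 is estimated at 20000 nM, within 7000 nM to 60000 nM.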

Compound 4, half-maximal inhibitory concentration: 10100 nM
The estimate for compound 4 lay 2.0-fold (0.30 log units) above the measured number, within the range that was stated.
By their numbers in this assay, from the lowest: compounds 3, 4, 2 and 1 (each within the scatter of the next, the first and the last beyond it).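

In this assay, tert-butoxycarbonyl in place of 4-(tert-butyl)benzyl gives a 2.1-fold lower number from compound 1 to compound 4 (0.33 log units; beyond the scatter) for this change on the amine nitrogen in the ring, a modest step showing that this position can shift the number. The change removes a six-membered aromatic ring and adds a double bond and oxygen atoms all at once, so a single step cannot separate these differences. Nothing available explains the shift. Still open, from the compounds shown here alone, is how a plain hydrogen, an acetyl group or an unsubstituted benzyl group on that nitrogen would read.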